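The source may report more compounds than this note shows. Statements on the series, on what has been measured and on what is new or still open speak of the compounds shown alone.

Working notes on the series, read in a functional assay on HEK293 cells for antagonist activity at 5-hydroxytryptamine receptor 6 (Homo sapiens), read by cAMP accumulation, with stated times of 10 min and 1 h; on this read-out higher numbers stand for weaker inhibition and lower numbers for stronger inhibition.

compound 1 `COc1cc(C)c(Cl)cc1S(=O)(=O)n1c(C)c(/C=N/N2CCN(C)CC2)c2ccccc21` gives 2400 nM
compound 2 `COc1cc(C)c(Cl)cc1S(=O)(=O)n1c(-c2ccccc2)c(/C=N/N2CCN(C)CC2)c2ccccc21` gives 7400 nM
compound 3 `CN1CCN(/N=C/c2c(-c3ccccc3)n(S(=O)(=O)c3cccc4c(N(C)C)cccc34)c3ccccc23)CC1` gives 1400 nM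

Compound 2 holds the highest number of the three. For the measured compounds named here, the single one-place step among the measured compounds is a 3.1-fold higher number from compound 1 to compound 2 (0.49 log units; beyond the scatter), arising from phenyl in place of methyl on an aromatic carbon. Going by the values given here, compound 3 carries the same phenyl as compound 2 but a different aryl on the sulfonyl sulfur; no one-place step links the two, and their numbers alone show that compound 3 gives 1400 nM whereas compound 2 gives 7400 nM.

Compound 4 `CN1CCN(/N=C/c2c(-c3ccccc3)n(S(=O)(=O)c3cccc4c3OCCO4)c3ccccc23)CC1` differs from compound 2 by 2,3-dihydro-1,4-benzodioxin-5-yl in place of 5-chloro-2-methoxy-4-methylphenyl on a sulfonyl sulfur. Among the compounds with values here, no measured step changes the group on the sulfonyl sulfur in one place, so the step of a 3.1-fold higher number from compound 1 to compound 2 (0.49 log units; beyond the scatter), which sits elsewhere on the core, does not bear on this change. The comparison of compound 2 with compound 3 only indicates that another aryl on the sulfonyl sulfur can go with a lower number. Compound 4 is therefore expected to land near 4500 nM, within 1500 nM to 14000 nM. The expected step is a 1.6-fold lower number from compound 2 to compound 4 (0.22 log units; within the scatter), with the direction uncertain and the size possibly within the scatter.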

Compound 4, half-maximal inhibitory concentration: 3800 nM
The estimate for compound 4 lay 1.2-fold (0.07 log units) above the measured number, and the stated range covers the measured number.
By their numbers in this assay, from the lowest: compounds 3, 1, 4 and 2 (each within the scatter of the next, the first and the last beyond it).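

For the compounds shown here, on a sulfonyl sulfur whose other neighbour is aromatic nitrogen, 2,3-dihydro-1,4-benzodioxin-5-yl in place of 5-chloro-2-methoxy-4-methylphenyl gives a 1.9-fold lower number from compound 2 to compound 4 (0.29 log units; within the scatter), the first one-place reading of this position in this assay. The exchange keeps 10 heavy atoms on each side, while chlorine leaves, the second oxygen enters, and the hydrogen-bond acceptors go from 1 to 2; this aryl exchange on the sulfonyl sulfur therefore does not separate the two compounds beyond the scatter. No measurement at hand bears on what lies behind this reading.

From the compounds shown here alone, it remains open whether phenyl in place of methyl on the aromatic carbon, seen as a 3.1-fold higher number from compound 1 to compound 2 (0.49 log units; beyond the scatter) with 5-chloro-2-methoxy-4-methylphenyl on the sulfonyl sulfur, reads the same way with 2,3-dihydro-1,4-benzodioxin-5-yl there. An unsubstituted phenyl or a pyridin-3-yl on the sulfonyl sulfur also lies outside the compounds shown, so the reading of this position rests on a single one-place step.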